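The source may hold more compounds than are shown below. What is called first, only, known or untested is meant among the compounds shown, and "the series" means these compounds.

Values so far in a functional assay on HCT-116 cells (Homo sapiens) for inhibition, read by colorimetric assay, with a stated time of 3 days; on this read-out lower numbers stand for stronger inhibition and higher numbers for weaker inhibition:
Compound 1 `O=C(CCCCCCNC(=O)C(O)(O)C(F)(F)F)Nc1ccccc1Br` gives 14500 nM
Compound 2 `O=C(CCCCCCNC(=O)C(O)(O)C(F)(F)F)Nc1ccccc1` gives 9140 nM
Compound 3 `CC(=O)c1ccc(NC(=O)CCCCCCNC(=O)C(O)(O)C(F)(F)F)cc1` gives 12100 nM

Compound 3 at 12100 nM sits in a tight group with no real separation from the other two compounds, since a 1.2-fold lower number from compound 1 to compound 3 (0.08 log units; within the scatter) and a 1.3-fold higher number from compound 2 to compound 3 (0.12 log units; within the scatter) are both differences that repeat measurements could produce on their own.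

Compound 4 `COc1cccc(NC(=O)CCCCCCNC(=O)C(O)(O)C(F)(F)F)c1` carries 3-methoxyphenyl in place of 4-acetylphenyl on an amide-type nitrogen. For the measured compounds named here, no measured compound has this methoxy group, so no step speaks to it directly. The nearest evidence comes from changes to the same aromatic end: hydrogen in place of bromo gave a 1.6-fold lower number from compound 1 to compound 2 (0.20 log units; within the scatter) and acetyl in place of hydrogen gave a 1.3-fold higher number from compound 2 to compound 3 (0.12 log units; within the scatter) within these three compounds.

The expected step is a 1.1-fold lower number from compound 3 to compound 4 (0.02 log units; within the scatter) and so none beyond the scatter in this assay on this limited evidence. For compound 4 the estimated value is 11500 nM with an expected range of 6000 nM to 22000 nM in this read-out.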

Compound 4, half-maximal inhibitory concentration: 6110 nM
Compound 4: the middle estimate sits 1.9-fold (0.27 log units) above what was measured; the measured number falls inside the stated range.
By their numbers in this assay, from the lowest: compounds 4, 2, 3 and 1 (each within the scatter of the next, the first and the last beyond it).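

In this assay, for the compounds shown here, the only step at this aromatic end that clears the scatter is the swap of 2-bromophenyl for 3-methoxyphenyl on the amide-type nitrogen, and it is modest: a 2.4-fold lower number from compound 1 to compound 4 (0.38 log units; beyond the scatter). The other two steps, a 2.0-fold lower number from compound 3 to compound 4 (0.30 log units; within the scatter) and a 1.5-fold lower number from compound 2 to compound 4 (0.17 log units; within the scatter), stay within the scatter, so compound 4 cannot be separated from compound 2 or compound 3, and only the gap to compound 1 is real. No measurements are available that could explain this gap.

As far as these compounds go, it remains open whether an amine or a carboxylic acid on the aromatic ring, or a longer chain in the shared core, would give a larger step. Whether any change at this end can move the number far beyond this small difference is also unsettled.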